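The source may hold more compounds than are shown below. What is called first, only, known or untested is meant among the compounds shown, and "the series" means these compounds.

In a functional assay on A549 cells (Homo sapiens) for antiproliferative activity, read by MTT assay (on this read-out lower numbers stand for stronger inhibition and higher numbers for weaker inhibition), compound 2 `O=C(Nc1ccc(F)cc1)Nc1cccc(CNc2ncnc3ccccc23)c1` gives 21000 nM, within the scatter of compound 1 `COc1ccc(NC(=O)Nc2cccc(CNc3ncnc4ccccc34)c2)cc1` at 29300 nM. The next change leads to compound 3 `O=C(Nc1cccc(CNc2ncnc3ccccc23)c1)Nc1cccc(C(F)(F)F)c1`, with 3-(trifluoromethyl)phenyl in place of 4-fluorophenyl on an amide-type nitrogen. Going by the values given here, the only measured step that bears on this is fluoro in place of methoxy on an aromatic carbon, a 1.4-fold lower number from compound 1 to compound 2 (0.14 log units; within the scatter). Among the compounds with values here, the data hold no measured trifluoromethyl example, so no shift beyond the scatter is expected in this assay. The expected step is a 1.4-fold lower number from compound 2 to compound 3 (0.15 log units; within the scatter). For compound 3 the estimate is 15000 nM, with an expected range of 6000 nM to 35000 nM.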

Compound 3, half-maximal inhibitory concentration: 44200 nM
Compound 3: the middle estimate sits 2.9-fold (0.47 log units) below what was measured; the measured number lies above the stated range.
By their numbers in this assay, from the lowest: compounds 2, 1 and 3 (each within the scatter of the next, the first and the last beyond it).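

In this assay, going by these compounds alone, the aryl group on the amide-type nitrogen now gives a first step beyond the scatter: 3-(trifluoromethyl)phenyl in place of 4-fluorophenyl gives a 2.1-fold higher number from compound 2 to compound 3 (0.32 log units; beyond the scatter) and is a modest change. The same group in place of 4-methoxyphenyl gives a 1.5-fold higher number from compound 1 to compound 3 (0.18 log units; within the scatter) and stays within the scatter, so this position has so far produced only a small separation. No measured evidence accounts for this step.

The compounds shown do not separate the trifluoromethyl group from its place on the phenyl ring. Going by these compounds, how an unsubstituted phenyl, or a phenyl carrying an amine or a carboxylic acid, would read on this nitrogen remains open.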